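The compounds below may be only part of what the source reports. "The series", "measured", "known", "first", "only" and "open" are said of these compounds alone.

Measured so far:
compound 1, `C#CCSc1nc(Sc2nnnn2CCN(C)C)c(C#N)c(-c2cccc(Cl)c2)n1`: 8640 nM
compound 2, `C#CCSc1nc(Sc2nccs2)c(C#N)c(-c2ccc(C)cc2)n1`: 2450 nM

In a functional assay on SMMC-7721 cells (Homo sapiens) for antiproliferative activity, read by MTT assay, with a stated time of 72 h (on this read-out higher numbers stand for weaker inhibition and lower numbers for stronger inhibition), compound 1 gives 8640 nM, the highest of the two numbers. The nearest is compound 2 at 2450 nM, a gap beyond the usual scatter. Going by the values given here, the two differ in more than one place, so no single-change step between measured compounds is available, and nothing in the present data fixes how much the placement of the chlorine on the aryl group alone moves the read-out.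

Compound 3, `C#CCSc1nc(Sc2nnnn2CCN(C)C)c(C#N)c(-c2ccc(Cl)cc2)n1`, is not yet measured. Relative to compound 1 the change is 4-chlorophenyl in place of 3-chlorophenyl on an aromatic carbon. The only support for an expectation is the value of compound 1 itself, so only a small step is expected, if any, most likely within the scatter, with a slight lean toward a lower number.

Compound 3 is expected to give about 6500 nM in this assay, in the range 2500 nM to 17000 nM. The step of a 1.3-fold lower number from compound 1 to compound 3 (0.12 log units; within the scatter) is the estimated outcome.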

Compound 3, half-maximal inhibitory concentration: 7340 nM
Compound 3: the middle estimate sits 1.1-fold (0.05 log units) below what was measured, within the range that was stated.
By their numbers in this assay, from the lowest: compound 2; then compounds 3 and 1 (each within the scatter of the next).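

Exchanging 3-chlorophenyl for 4-chlorophenyl on this aromatic carbon gives a 1.2-fold lower number from compound 1 to compound 3 (0.07 log units; within the scatter) in this assay, the first single-change step available in the series. With the rest of the molecule held fixed, these two chlorine placements cannot be told apart on this read-out, so the choice between them does not separate the two compounds here. No measurement is available that would explain this outcome.

Still open, on these data alone, is what an amine, a carboxylic acid or a longer alkyl chain in place of the chlorine would do at this position. It is also unknown whether the two chlorine placements would read alike when the other groups on the shared core are changed, for example with a thiazole in place of the present sulfur-linked group.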